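Working notes: fluoro on the pendant phenyl

The source may report more compounds than this note shows. Statements on the series, on what has been measured and on what is new or still open speak of the compounds shown alone.

Measured so far:
- Compound 1 `COc1ccc(-c2ccc3ncn(-c4cc(OC)c(OC)c(OC)c4)c3c2)cc1O`: in a functional assay on SGC-7901 cells (Homo sapiens) for antiproliferative activity, read by MTT assay, with a stated time of 72 h (on this read-out lower numbers stand for stronger inhibition and higher numbers for weaker inhibition), compound 1 gives 44 nM.
- Compound 2 `COc1cc(-n2cnc3ccc(-c4ccccc4)cc32)cc(OC)c1OC`: in this assay compound 2 gives 290 nM.

Compound 2 stands at the highest of the two numbers in this assay; its nearest neighbour is compound 1, separated by the step of a 6.6-fold higher number from compound 1 to compound 2 (0.82 log units; beyond the scatter), which is phenyl in place of 3-hydroxy-4-methoxyphenyl on an aromatic carbon.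

Compound 3 `COc1cc(-n2cnc3ccc(-c4cccc(F)c4)cc32)cc(OC)c1OC` is the next variant and has not been measured. Within the data shown here, it differs from compound 2 by fluoro in place of hydrogen on an aromatic carbon, on the same six-membered aromatic ring of carbon only that carried the earlier change.

Among the measured compounds shown here, no measured step involves a fluoro group, so nothing bears directly on this change. For the measured compounds named here, the only step available, a 6.6-fold higher number from compound 1 to compound 2 (0.82 log units; beyond the scatter), concerns a different substitution of the same ring and is modest in size. A single fluorine is a far smaller alteration than that one, so the expectation for compound 3 in this assay is a step of a 1.2-fold lower number from compound 2 to compound 3 (0.06 log units; within the scatter), not clearly beyond the scatter in either direction.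

For compound 3 the estimate in this assay is 250 nM, with a range from 100 nM to 700 nM.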

Compound 3, half-maximal inhibitory concentration: 2490 nM
Estimate against measurement, compound 3: 10-fold (1.00 log units) below; measured number above the stated range.
By their numbers in this assay, from the lowest: compound 1; then compound 2; then compound 3.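

Fluoro in place of hydrogen on this ring is not a silent change: in this assay it gives an 8.6-fold higher number from compound 2 to compound 3 (0.93 log units; beyond the scatter), the first sign that a substituent at this place, meta to a large group, can raise the number as well as lower it. Among these compounds, the pendant ring therefore works in both directions around the unsubstituted phenyl of compound 2, with the 3-hydroxy-4-methoxyphenyl of compound 1 at the low end and the 3-fluorophenyl of compound 3 at the high end, and the exchange between these two groups gives a 57-fold higher number from compound 1 to compound 3 (1.75 log units; beyond the scatter) as the largest step so far. Nothing available here speaks to the reason for this rise.

The compounds shown leave open whether the rise belongs to fluoro itself or to any group at this place on the ring, and which part of the 3-hydroxy-4-methoxyphenyl goes with the low number of compound 1. A 3-chlorophenyl, a 3-aminophenyl, a 3-hydroxyphenyl and a 4-methoxyphenyl on the same core would separate these readings.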